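Swapping the acetyl for a dimethylamino group

The source may report more compounds than this note shows. Statements on the series, on what has been measured and on what is new or still open speak of the compounds shown alone.

Measured compounds:
- compound 1, `COc1cc(C)cc(-c2c(-c3ccnc(-c4ccc(C(C)=O)cc4)c3)cnn2CC#N)c1`, gives 71% in a functional assay on Hs-578T cells (Homo sapiens) for cytotoxicity, read by sulforhodamine B assay, with a stated time of 48 h, tested at 100 nM; on this read-out lower numbers stand for a stronger effect and higher numbers for a weaker effect at the one concentration tested
- compound 2, `Cc1cc(O)cc(-c2nn(CC#N)cc2-c2ccnc(-c3ccc(Oc4ccccc4)cc3)c2)c1`, gives 82% in this assay
- compound 3, `COc1cc(C)cc(-c2nn(CC#N)cc2-c2ccnc(-c3ccc(N(C)C)cc3)c2)c1`, gives -19% in this assay

Among the three numbers in this assay, compound 1 stands second highest. Its nearest neighbour is compound 2, whose number is higher by an amount beyond the scatter; its furthest is compound 3, whose number is far lower, again beyond the scatter. Compound 3 is therefore the compound with the strongest effect of the three in this assay.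

The step now followed leads from compound 1 to compound 4, `COc1cc(C)cc(-c2c(-c3ccnc(-c4ccc(N(C)C)cc4)c3)cnn2CC#N)c1`, which is not yet measured. The change is dimethylamino in place of acetyl on an aromatic carbon. For the measured compounds named here, no pair among the measured compounds differs in this single place, so the size of this step is not known from direct comparison. Compound 3 also carries a dimethylamino group on its outer aromatic ring and gives -19% in this assay, but it differs from compound 4 elsewhere as well, so only its value can be noted.

On that basis, compound 4 is expected to show a step of a number 41 percentage points lower from compound 1 to compound 4 (beyond the scatter) toward a stronger effect in this assay. Compound 4 is estimated at 30%, within a range from -20% to 75%.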

Compound 4, a percentage reported as activity, at one concentration (the size of the read-out at that concentration, not a potency): 23%
Beside the measured number, compound 4's estimate is 7 percentage points above it, and the stated range covers the measured number.
By their numbers in this assay, from the lowest: compound 3; then compound 4; then compound 1; then compound 2.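

In this assay, the exchange of acetyl for dimethylamino on the outer aromatic ring gives a step of a number 48 percentage points lower from compound 1 to compound 4 (beyond the scatter), the first direct reading of a single change among these compounds. It shows that this place, an aromatic carbon para to a large group, is not indifferent to what sits there: the 4-acetylphenyl to 4-(dimethylamino)phenyl exchange moves the read-out toward a stronger effect, with the rest of the molecule unchanged. The two groups match in heavy-atom count, hydrogen-bond donors and hydrogen-bond acceptors, so those counts do not separate them, and nothing given here explains the step.

As far as these compounds go, what stays open is whether this shift belongs to dimethylamino specifically or would also appear with a primary amine, a methoxy group or a longer chain such as diethylamino at the same place. From the compounds shown here alone, it is also open whether a ring amine such as morpholine would fit this pattern, and whether the same exchange would give a step of similar size on other cell lines.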